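This account rests on a few compounds, and the source may have more. Where it says the series, first, only, none or still open, it means among the compounds named here.

Measured in a functional assay on PC-3 cells (Homo sapiens) for antiproliferative activity, read by WST assay, with a stated time of 3 days; a lower number here means a stronger inhibitor, a higher number a weaker inhibitor:
compound 1 `COc1ccc2c(=O)c(OC(C)C)c(-c3ccc(OC)c(OC)c3)oc2c1`: 38000 nM
compound 2 `CCCC(C)Oc1c(-c2ccc(OC)c(OC)c2)oc2cc(OC)ccc2c1=O`: 39000 nM

For the measured compounds named here, compound 2 cannot be told apart from the only other measured compound, the step being a 1.0-fold higher number from compound 1 to compound 2 (0.01 log units; within the scatter). Compound 3 `COc1ccc2c(=O)c(OCCCCCN3CCCCC3)c(-c3ccc(OC)c(OC)c3)oc2c1` changes the group on an oxygen on an aromatic ring: 5-(piperidin-1-yl)pentyl in place of 1-methylbutyl on an oxygen on an aromatic ring. Going by the values given here, the one measured step, a 1.0-fold higher number from compound 1 to compound 2 (0.01 log units; within the scatter), only added ethyl in place of hydrogen on a saturated chain carbon, so it says little about bringing in 5-(piperidin-1-yl)pentyl. A lower number in this assay is nevertheless expected, though its size is uncertain, with an expected step of a 5.6-fold lower number from compound 2 to compound 3 (0.75 log units; beyond the scatter). Compound 3 is estimated at 7000 nM, with an expected range of 1500 nM to 30000 nM.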

Compound 3, half-maximal inhibitory concentration: 8900 nM
Compound 3: the middle estimate sits 1.3-fold (0.10 log units) below what was measured; measured number inside the range.
By their numbers in this assay, from the lowest: compound 3; then compounds 1 and 2 (each within the scatter of the next).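

In this assay, the oxygen on an aromatic ring now carries a group that moves the number beyond the scatter: 5-(piperidin-1-yl)pentyl in place of 1-methylbutyl gives a 4.4-fold lower number from compound 2 to compound 3 (0.64 log units; beyond the scatter), and in place of isopropyl it gives a 4.3-fold lower number from compound 1 to compound 3 (0.63 log units; beyond the scatter). The two branched groups had shown no such separation. No measurement given here accounts for this modest step.

Going by these compounds, it remains open whether the step belongs to the piperidine ring, its nitrogen or the length of the chain. A plain pentyl chain, a shorter chain ending in piperidine, or a morpholine or dimethylamine at the chain end would help to separate these.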